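Cytotoxicity of two aryl ethers and a benzyloxy analogue

The compounds below may be only part of what the source reports. "The series", "measured", "known", "first", "only" and "open" are said of these compounds alone.

Of the compounds shown here, two have numbers so far. Compound 1 `CN(C)CCNc1ccnc2cc(OCc3ccccc3)ccc12` was tested in a functional assay on HepG2 cells (Homo sapiens) for cytotoxicity, read by MTT assay, with a stated time of 48 h (a higher number here means a weaker inhibitor, a lower number a stronger inhibitor), and gives 3120 nM. Compound 2 `CCCCCCOc1ccc2c(Cl)ccnc2c1`, which carries a hexyloxy chain on the shared core, gives in this assay a value of 2420 nM. Against this background compound 2 stands within the usual scatter of compound 1: no difference between the two can be read from these numbers, and no step between them is counted.

The next compound to be measured is compound 3 `Clc1ccnc2cc(OCc3ccccc3)ccc12`. It differs from compound 2 by phenyl in place of pentyl on a saturated chain carbon bound to an oxygen on an aromatic ring; the chloro substituent and the core are kept. Among the compounds with values here, no measured pair describes this change, so the expectation can only lean on the values of compound 1 and compound 2, which already span a benzyloxy and an alkoxy ether on the same core. On that basis the step from compound 2 to compound 3 is expected to be small, a 1.2-fold higher number from compound 2 to compound 3 (0.08 log units; within the scatter), and not to rise above the scatter in either direction. The estimate for compound 3 in this assay is 2900 nM, with a range from 1200 nM to 7500 nM.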

Compound 3, half-maximal inhibitory concentration: 2680 nM
Beside the measured number, compound 3's estimate is 1.1-fold (0.03 log units) above it; measured number inside the range.
By their numbers in this assay, from the lowest: compounds 2, 3 and 1 (each within the scatter of the next).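

In this assay, phenyl in place of pentyl on a saturated chain carbon bound to an oxygen on an aromatic ring leaves the number within the scatter (a 1.1-fold higher number from compound 2 to compound 3 (0.04 log units; within the scatter)). Within the data shown here, this is the first reading at this place from a single change, since compound 1 and compound 2 differ in more than one place, and it shows no difference between the aromatic ring and the open chain on the ether. A second single change, chloro in place of (2-(dimethylamino)ethyl)amino on an aromatic carbon, also stays within the scatter with the benzyloxy ether held constant (a 1.2-fold lower number from compound 1 to compound 3 (0.07 log units; within the scatter)), so neither place yet shows any effect on the number in this series.

Still open, on these data alone, is whether a longer chain, a terminal amine or a carboxylic acid on the ether, or a morpholine or a shorter amine chain on that aromatic carbon, would give a step beyond the scatter. Nothing measured bears on why these three compounds read alike.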